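The compounds below may be only part of what the source reports. "The series", "measured", "known", "first", "only" and "open" are said of these compounds alone.

Compound 2 `Nc1scc(CN2CCN(c3cccc(F)c3)CC2)c1C(=O)c1ccc(Cl)cc1` carries a 3-fluorophenyl group on an amine nitrogen in a ring. In an assay on CHO cells for displacement of a labelled ligand from adenosine receptor A3 (Homo sapiens), read by scintillation counting, with a stated time of 120 min, tested at 10 uM (on this read-out lower numbers stand for less inhibition and higher numbers for more inhibition at the one concentration tested (going by the name of the read-out)), compound 2 gives 4%. Compound 1 `Nc1scc(CN2CCN(c3ccncc3)CC2)c1C(=O)c1ccc(Cl)cc1` differs from it only in the group on that ring nitrogen, and in this assay compound 1 gives 2%; the two values lie within the scatter of each other, so nothing separates them. Compound 3 `Nc1scc(CN2CCN(c3c(F)cccc3F)CC2)c1C(=O)c1ccc(Cl)cc1` has not yet been measured. Its change from compound 2 is 2,6-difluorophenyl in place of 3-fluorophenyl on an amine nitrogen in a ring. Going by the values given here, the only measured step that touches this position is a number 2 percentage points higher from compound 1 to compound 2 (within the scatter), and it moved nothing beyond the scatter. These numbers point in no direction, so for compound 3 no step beyond the scatter is expected, an estimated no change at the digits printed from compound 2 to compound 3 (within the scatter). Compound 3 is therefore expected to give about 4%, in a range from -6% to 14%.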

Compound 3, a percentage reported as inhibition, at one concentration (the size of the read-out at that concentration, not a potency): 4%
Beside the measured number, compound 3's estimate shows no gap at the digits printed, and the stated range covers the measured number.
By their numbers in this assay, from the lowest: compounds 1, 2 and 3 (each within the scatter of the next).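

In this assay, the swap of 3-fluorophenyl for 2,6-difluorophenyl on the ring nitrogen gives no change at the digits printed from compound 2 to compound 3 (within the scatter), so this second fluorine substitution shows no effect that can be told apart from the scatter. Against the pyridin-4-yl group, the result is a number 2 percentage points higher from compound 1 to compound 3 (within the scatter), which means that three different aromatic rings at this position now stand within the scatter of one another, all with little inhibition at the one concentration tested. No available evidence bears on why this position responds so little.

All three groups shown here are six-membered aromatic rings, so it remains open whether a non-aromatic group on this nitrogen, such as a benzyl group, an acetyl group or a chain ending in a carboxylic acid, would give a different number. On these data alone, the rest of the core is the same in all three compounds, so the effect of changes elsewhere also remains open.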